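Chain Swap on the Anilino Nitrogen of a Shared Core

The compounds below may be only part of what the source reports. "The series", "measured", "known", "first", "only" and "open" are said of these compounds alone.

Measured compounds:
compound 1, `CSc1nc(-c2ccc(F)cc2)c(-c2ccnc(N[C@@H](C)C3CCCCC3)c2)[nH]1`, a functional assay on blood (Homo sapiens) for inhibition; a higher number here means a weaker inhibitor, a lower number a stronger inhibitor: "not determined" (no result reported)
compound 2, `CSc1nc(-c2ccc(F)cc2)c(-c2ccnc(NC(CO)C(C)C)c2)[nH]1`, this assay: "not determined" (no result reported)
compound 3, `CSc1nc(-c2cccc(C(F)(F)F)c2)c(-c2ccnc(NC(C)C(C)C)c2)[nH]1`, this assay: 1360 nM

Three compounds share a common core and differ in the aryl group on one side and in the substituent on the nitrogen on an aromatic ring. For compound 1 the result in this assay is "not determined" (no result reported), so it stands nowhere on the numbers: no single value exists for it, and compound 2 is in the same position with "not determined" (no result reported). Within the data shown here, the only number in the set belongs to compound 3, which in this assay gives 1360 nM.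

Compound 4, `CSc1nc(-c2ccc(F)cc2)c(-c2ccnc(NC(C)CCc3ccccc3)c2)[nH]1`, is derived from compound 1 by a change on the nitrogen on an aromatic ring: 1-methyl-3-phenylpropyl in place of 1-cyclohexylethyl on a nitrogen on an aromatic ring. Among the measured compounds shown here, since compound 1 carries no value, no step to compound 4 can be sized; the expectation for compound 4 is that it lands in the same region as compound 3, because compound 3 gives 1360 nM with a branched alkyl chain on the same nitrogen, and the change in compound 4 is not expected to move it beyond the usual scatter of that region.

Compound 4 is therefore estimated at 1500 nM in this assay, with a range from 300 nM to 8000 nM.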

Compound 4, half-maximal inhibitory concentration: 2370 nM
Estimate against measurement, compound 4: 1.6-fold (0.20 log units) below; low and high end bracket the measured number.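

Compound 1 has no single number in this assay and compound 4 gives 2370 nM there, so no step can be read between them. The compounds shown leave open what the swap of 1-cyclohexylethyl for 1-methyl-3-phenylpropyl alone does to inhibition on the shared core. No supporting data bear on this result.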